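Chain Length and Oral Effect in the Dog

The compounds below may be only part of what the source reports. "The series", "measured", "known", "first", "only" and "open" are said of these compounds alone.

Compound 1 `CCc1nc2c(OCc3ccccc3)cccn2c1N`: 59%
Compound 2 `CCCc1nc2c(OCc3ccccc3)cccn2c1N`: 0%
Compound 3 `CCNc1c(C)nc2c(OCc3ccccc3)cccn12`: 68%

Of the compounds shown here, three have so far been tested in a functional assay on the whole organism with Canis familiaris (Canis lupus familiaris) as the target, at a dose of 8 mg/kg by the oral route; on this read-out lower numbers stand for a weaker effect and higher numbers for a stronger effect at the one dose given. Compound 1 and compound 2 differ in one place only: methyl in place of hydrogen on a saturated chain carbon, two bonds along the chain from an aromatic carbon. That single change produced a number 59 percentage points lower from compound 1 to compound 2 (beyond the scatter), so a one-carbon lengthening of the chain on the core of compound 1 all but removed the effect at the dose used.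

Compound 3 carries a different core; how its core differs from that of compound 1 is not broken down here. The values of compound 3 and compound 1 in this assay lie within the usual scatter of each other, so nothing can be said about which of the two is the stronger. Compound 2 lies well below both.

Compound 4 `CCCNc1c(C)nc2c(OCc3ccccc3)cccn12` has not yet been measured. It differs from compound 3 by methyl in place of hydrogen on a saturated chain carbon, two bonds along the chain from a nitrogen on an aromatic ring. Going by the values given here, this is the same kind of change as the one from compound 1 to compound 2, but not the same: there the added methyl sat two bonds along the chain from an aromatic carbon, here it sits two bonds along the chain from a nitrogen on an aromatic ring. The expectation for compound 4 in this assay rests on the earlier step of a number 59 percentage points lower from compound 1 to compound 2 (beyond the scatter), with the surroundings of the change leaving the size uncertain. For compound 4 the expected step is a number 48 percentage points lower from compound 3 to compound 4 (beyond the scatter). Compound 4 is therefore estimated at 20%, expected to fall between 0% and 55%.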

Compound 4, a percentage reported as inhibition, in the whole organism at one dose (the size of the read-out at that dose, not a potency): 68%
For compound 4 the middle estimate is 48 percentage points below the measured one; the measured number lies above the stated range.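

In this assay, the change from ethylamino to propylamino on the core of compound 3 gave no change at the digits printed from compound 3 to compound 4 (within the scatter), so the longer chain that all but removed the effect on the core of compound 1 cost nothing measurable here. Setting the two steps side by side shows that this change cannot be carried from one core to the other in this series and be expected to have the same size: the same change on two cores in this assay, a number 59 percentage points lower (beyond the scatter) from compound 1 to compound 2 and no change at the digits printed (within the scatter) from compound 3 to compound 4, 59 percentage points apart, beyond the scatter of two such steps With only one pair on each core, this does not show why the two steps part ways, since the pairs differ both in the core and in whether the chain starts from an aromatic carbon or from a nitrogen on an aromatic ring, and each number is a read-out at a single dose rather than a potency.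

The compounds shown leave open how a still longer chain, such as butyl on the core of compound 1 or butylamino on the core of compound 3, would read at this dose. They also leave open whether a propyl chain on the core of compound 3, joined through carbon rather than through the nitrogen, would follow compound 2 or compound 4.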